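Adding a methyl to the anilide ring of compound 3

The source may report more compounds than this note shows. Statements on the series, on what has been measured and on what is new or still open speak of the compounds shown alone.

Compound 3 `COc1cc2c(Nc3nc4ccc(C(=O)Nc5c(C)cccc5C)cc4s3)ncnc2cc1OCCCN1CCCCC1` sits second highest of the three numbers in a functional assay on K562 cells (Homo sapiens) for cytotoxicity, read by WST assay, with a stated time of 72 h (on this read-out lower numbers stand for stronger inhibition and higher numbers for weaker inhibition), where compound 3 gives 13700 nM. For the measured compounds named here, compound 2 `COc1cc2c(Nc3nc4ccc(C(=O)Nc5c(C)cccc5Cl)cc4s3)ncnc2cc1OCCCN1CCC(C)CC1` gives 8300 nM, within the scatter of compound 3, while compound 1 `CCN(CC)CCCOc1cc2ncnc(Nc3nc4ccc(C(=O)Nc5c(C)cccc5C)cc4s3)c2cc1OC` gives 28400 nM; the only single change measured, a 2.1-fold lower number from compound 1 to compound 3 (0.32 log units; beyond the scatter), concerns the amine at the end of the chain. Compound 4 `COc1cc2c(Nc3nc4ccc(C(=O)Nc5c(C)cc(C)cc5C)cc4s3)ncnc2cc1OCCCN1CCCCC1` differs from compound 3 by methyl in place of hydrogen on an aromatic carbon, turning 2,6-dimethylphenyl into 2,4,6-trimethylphenyl. Going by the values given here, no measured step touches that ring, so nothing here sets a direction. The step of a 1.1-fold lower number from compound 3 to compound 4 (0.06 log units; within the scatter) is therefore expected to stay within the scatter. Compound 4 is estimated at 12000 nM, between 5000 nM and 30000 nM.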

Compound 4, half-maximal inhibitory concentration: 9300 nM
Estimate against measurement, compound 4: 1.3-fold (0.11 log units) above, within the range that was stated.
By their numbers in this assay, from the lowest: compounds 2, 4 and 3 (each within the scatter of the next); then compound 1.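

In this assay, for the compounds shown here, the change from 2,6-dimethylphenyl to 2,4,6-trimethylphenyl gives the first reading at this position (a 1.5-fold lower number from compound 3 to compound 4 (0.17 log units; within the scatter)). Methyl in place of hydrogen on this aromatic carbon, para to a large group, therefore stays within the scatter on this read-out. No evidence available here bears on this result.

As far as these compounds go, whether a methoxy group, a chlorine or a carboxylic acid at this carbon would take the number beyond the scatter remains open. So does whether methyl here would read the same alongside the diethylamino chain end of compound 1.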